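This account rests on a few compounds, and the source may have more. Where it says the series, first, only, none or still open, it means among the compounds named here.

Of the compounds shown here, three have been measured in a functional assay on DU-145 cells (Homo sapiens) for antiproliferative activity, read by sulforhodamine B assay, with a stated time of 48 h; a higher number here means a weaker inhibitor, a lower number a stronger inhibitor. Compound 1 `O=C1NCCN1c1ccc(S(=O)(=O)Nc2ccc3[nH]ccc3c2)cc1` gives 1370 nM, compound 2 `Cc1cccc(NS(=O)(=O)c2ccc(N3CCNC3=O)cc2)c1` gives 580 nM, and compound 3 `CCc1cccc(NS(=O)(=O)c2ccc(N3CCNC3=O)cc2)c1` gives 730 nM. The number for compound 3 is the second highest of the three, although its gaps to compound 2 and to compound 1 both lie within the scatter.

The next compound to be tested is compound 4 `O=C1NCCN1c1ccc(S(=O)(=O)Nc2cccc(Br)c2)cc1`. Its structural difference from compound 3 is bromo in place of ethyl on an aromatic carbon, which amounts to bromo in place of ethyl on an aromatic carbon, meta to a large group. Within the data shown here, only one measured step bears on this change: a 1.3-fold higher number from compound 2 to compound 3 (0.10 log units; within the scatter). That step, methyl in place of hydrogen on a saturated chain carbon bound to an aromatic carbon, alters the same substituent and stays within the scatter. Among the measured compounds shown here, no measured compound carries bromo, so the data offer no direct precedent for this exchange, and the evidence is thin. With only the small step to compound 3 at 730 nM to go on, no shift beyond the scatter is expected in this assay, and no direction can be favoured with confidence. The expected step is a 1.0-fold lower number from compound 3 to compound 4 (0.02 log units; within the scatter). For compound 4 the estimated value is 700 nM, with an expected range of 300 nM to 1600 nM.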

Compound 4, half-maximal inhibitory concentration: 340 nM
Estimate against measurement, compound 4: 2.1-fold (0.31 log units) above, within the range that was stated.
By their numbers in this assay, from the lowest: compounds 4, 2, 3 and 1 (each within the scatter of the next, the first and the last beyond it).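

Until this result, the aromatic carbon meta to a large group had shown only the change from methyl to ethyl, a step that stayed within the scatter in this assay. Among these compounds, exchanging ethyl for bromo gives a 2.1-fold lower number from compound 3 to compound 4 (0.33 log units; beyond the scatter) and is thus the first modest change at this place to pass beyond the scatter. Set against methyl, however, the same bromo gives a 1.7-fold lower number from compound 2 to compound 4 (0.23 log units; within the scatter) so the result separates bromo from ethyl but not from methyl, and that separation rests on a single step, with no measurement here that accounts for it.

Chloro, methoxy or an amine on the same carbon would show whether bromo holds any particular standing at this place or whether other groups give numbers in the same range. A longer chain such as propyl would show whether the numbers continue to rise beyond ethyl, while bromo on another carbon of the ring would show whether this result depends on where the group sits.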